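Swapping methoxy for fluoro on the pendant phenyl ring

The compounds below may be only part of what the source reports. "The series", "measured", "known", "first", "only" and "open" are said of these compounds alone.

Of the compounds shown here, three sharing one core have been measured in a functional assay on NCI-H226 cells (Homo sapiens) for inhibition, read by sulforhodamine B assay, with a stated time of 48 h, tested at 10 uM; a higher number here means more inhibition at the concentration tested (going by the name of the read-out), a lower number less inhibition. Compound 1 `COc1ccc(-c2cn3ccnc3c(-c3ccc4ncn(C5CCCCC5)c4c3)n2)cc1` gives 35.9%. Compound 2 `Fc1ccc(-c2cn3ccnc3c(-c3ccc4ncn(C5CCCCC5)c4c3)n2)cc1`, obtained by fluoro in place of methoxy on an aromatic carbon, gives 23.3%, and the step of a number 12.6 percentage points lower from compound 1 to compound 2 (beyond the scatter). Compound 3 `COc1ccccc1-c1cn2ccnc2c(-c2ccc3ncn(C4CCCCC4)c3c2)n1`, where the cores differ by 2-methoxyphenyl in place of 4-methoxyphenyl on an aromatic carbon, gives 25.7%, so a number 10.2 percentage points lower from compound 1 to compound 3 (beyond the scatter); between compound 2 and compound 3 the step of a number 2.4 percentage points higher from compound 2 to compound 3 (within the scatter).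

Compound 4 `Fc1ccccc1-c1cn2ccnc2c(-c2ccc3ncn(C4CCCCC4)c3c2)n1` is not yet measured. It differs from compound 3 by fluoro in place of methoxy on an aromatic carbon, the same kind of change as that from compound 1 to compound 2, though here the place is ortho to a large group rather than para to a large group. Because the earlier step of a number 12.6 percentage points lower from compound 1 to compound 2 (beyond the scatter), a drop of similar kind is expected for compound 4, tempered since the surroundings of the place differ; the expected step is a number 7.7 percentage points lower from compound 3 to compound 4 (within the scatter). Compound 4 is therefore estimated at 18%, expected to lie between 8% and 30%.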

Compound 4, a percentage reported as inhibition, at one concentration (the size of the read-out at that concentration, not a potency): 28.7%
Compound 4: the middle estimate sits 10.7 percentage points below what was measured; measured number inside the range.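

In this assay, fluoro in place of methoxy does not carry over as a fixed step from one core to the other, and the two steps differ: the same change on two cores in this assay, a number 12.6 percentage points lower (beyond the scatter) from compound 1 to compound 2 and a number 3 percentage points higher (within the scatter) from compound 3 to compound 4, 15.6 percentage points apart, beyond the scatter of two such steps

Around compound 4 the numbers lie close together, with a number 3 percentage points higher from compound 3 to compound 4 (within the scatter), a number 5.4 percentage points higher from compound 2 to compound 4 (within the scatter) and a number 7.2 percentage points lower from compound 1 to compound 4 (within the scatter), so compound 4 cannot be ranked against any of the other three. This shows that the step seen with the group para to a large group cannot be assumed where the group is ortho to a large group, but with one pair on each core it does not show why the two steps differ or how the change would behave on any further core.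

The compounds shown carry only methoxy or fluoro on the pendant phenyl ring. As far as these compounds go, what an amine, a carboxylic acid or a longer chain there would give in this assay remains open.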